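The source may report more compounds than this note shows. Statements on the series, on what has been measured and on what is new or still open speak of the compounds shown alone.

Compound 2, with the structure `CCCCNC(=O)C1=Cc2ccc(OC)cc2OC1c1cc(OC)c(OC)c(OC)c1`, was tested in a functional assay for inhibition of nuclear factor NF-kappa-B complex (Homo sapiens) (on this read-out higher numbers stand for weaker inhibition and lower numbers for stronger inhibition), where compound 2 gives 25500 nM. Among the compounds with values here, its only measured companion is compound 1, `COc1ccc2c(c1)OC(c1cc(OC)c(OC)c(OC)c1)C(C(=O)Nc1ccccc1)=C2`, which in this assay gives 17500 nM. The two numbers cannot be told apart: the change a 1.5-fold higher number from compound 1 to compound 2 (0.16 log units; within the scatter) lies within the usual scatter, so compound 2 stands beside compound 1 rather than apart from it.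

Compound 3, `COc1ccc2c(c1)OC(c1cc(OC)c(OC)c(OC)c1)C(C#N)=C2`, has not yet been measured. Compared with compound 2 the change is cyano in place of butylcarbamoyl on a double-bonded ring carbon. Within the data shown here, the single measured step from compound 1 to compound 2 touched only the group on the amide nitrogen and moved the number by a 1.5-fold higher number from compound 1 to compound 2 (0.16 log units; within the scatter). That step does not test the loss of the whole amide, so it says little about compound 3. With nothing to suggest a shift in either direction, the expectation for compound 3 is a step of about a 1.0-fold lower number from compound 2 to compound 3 (0.01 log units; within the scatter) in this assay. For compound 3 the estimated value in this assay is 25000 nM, in a range from 8000 nM to 80000 nM.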

Compound 3, half-maximal inhibitory concentration: 3400 nM
Compound 3: the middle estimate sits 7.4-fold (0.87 log units) above what was measured; the measured number lies below the stated range.
By their numbers in this assay, from the lowest: compound 3; then compounds 1 and 2 (each within the scatter of the next).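

Within the data shown here, at the double-bonded ring carbon, the earlier step only exchanged the group on the amide nitrogen, whereas removing the whole amide gives the first changes beyond the scatter in this assay: a 7.5-fold lower number from compound 2 to compound 3 (0.88 log units; beyond the scatter) and a 5.1-fold lower number from compound 1 to compound 3 (0.71 log units; beyond the scatter). So this position does respond to what it carries, and the cyano compound inhibits more strongly than either amide, even though the butyl and phenyl amides cannot be told apart. The change from butylcarbamoyl to cyano alters several things at once, going from 7 heavy atoms to 2, from 1 hydrogen-bond donor to 0, and from a double bond outside aromatic rings to a triple bond, and no available evidence separates these differences or explains the gain.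

The compounds shown leave open how a carboxylic acid, a methyl ester or a plain hydrogen on this carbon would compare with the cyano group, which would help show whether the amide's absence or the nitrile's presence matters more. They also leave open whether the same step would appear if the methoxy groups on the shared core were replaced by hydroxyl groups.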